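A few compounds are considered here, and "the series" means these few. Any claim that something is new, unique, unknown or untested is made for them only; others in the source may bear on it.

Measured compounds in an ADME assay on MT4 cells (Homo sapiens) for cytotoxicity, read by MTT assay, with a stated time of 5 days; on this read-out higher numbers stand for lower toxicity in this test and lower numbers for higher toxicity in this test:
- compound 1 `N#Cc1ccc(Nc2nccc(N(CC3CCCC3)c3c(F)cc(-c4ccc(C#N)cc4)cc3F)n2)cc1` — gives > 247000 nM, which is a limit of this assay and not a number.
- compound 2 `N#Cc1ccc(Nc2nccc(N(CCCF)c3c(F)cc(-c4ccc(C#N)cc4)cc3F)n2)cc1` — gives 241000 nM.
- compound 3 `N#CCN(c1ccnc(Nc2ccc(C#N)cc2)n1)c1c(F)cc(-c2ccc(C#N)cc2)cc1F` — gives 206000 nM.

Compound 3 holds the lowest of the two numbers, with compound 2 nearest; the gap from compound 2 to compound 3 is a 1.2-fold lower number from compound 2 to compound 3 (0.07 log units; within the scatter). The remaining value, that of compound 1, is a limit (the limit of > 247000 nM in this assay, at which 1 of the 3 values shown sits), so the steps of an at least 1.0-fold lower number from compound 1 to compound 2 (0.01 log units; that floor lies within the scatter) and an at least 1.1-fold lower number from compound 1 to compound 3 (0.07 log units; that floor lies within the scatter) are only floors, and both floors lie within the scatter. Across the three measured compounds, cyclopentyl, 2-fluoroethyl and cyano on the saturated chain carbon bound to the ring nitrogen give readings that cannot be told apart.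

Compound 4 `CC(=O)N(c1ccnc(Nc2ccc(C#N)cc2)n1)c1c(F)cc(-c2ccc(C#N)cc2)cc1F` differs from compound 3 by acetyl in place of cyanomethyl on a nitrogen on an aromatic ring. Going by the values given here, no measured step exchanges a group directly on that nitrogen; the bearing steps are the three above, all flat. Compound 4 is therefore expected to sit with the others, the step of a 1.1-fold higher number from compound 3 to compound 4 (0.03 log units; within the scatter) estimated as none beyond the scatter. Compound 4 is expected to give about 220000 nM in this assay, within 110000 nM to 300000 nM, with a real chance that only a limit is reported.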

Compound 4, half-maximal cytotoxic concentration: > 268000 nM
Compound 4 was reported as a limit (the forecaster's own chance of this, stated with the estimate: 40%); middle value at least 1.2-fold (0.08 log units) from the limit.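

In this assay compound 4 gives > 268000 nM, which is a limit of the assay and not a number. Acetyl is the only group on this nitrogen in the series that is attached through a carbonyl, and this exchange brings no lower number: the steps are an at least 1.3-fold higher number from compound 3 to compound 4 (0.11 log units; that floor lies within the scatter) and an at least 1.1-fold higher number from compound 2 to compound 4 (0.04 log units; that floor lies within the scatter), so the carbonyl-linked group joins the chain-linked groups without any difference beyond the scatter being shown, although a larger real gap is not excluded. Both steps are only floors, and the step between compound 1 and compound 4 cannot be read, because the value of compound 4 is a limit: the limit of > 268000 nM in this assay, at which 1 of the 4 values shown sits.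

The series still leaves open whether any group on this nitrogen can bring the reading down beyond the scatter, since a primary amine on a short chain or a carboxylic acid on a short chain would test the position with quite different atoms. Going by these compounds, how far compound 4 and compound 1 truly lie from compound 2 and compound 3 also stays open until a test range reaching past both limits gives numbers.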